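The source may hold more compounds than are shown below. What is called first, only, known or untested is meant among the compounds shown, and "the series" means these compounds.

Measured in a functional assay on HepG2 cells (Homo sapiens) for antiproliferative activity, read by MTT assay, with a stated time of 48 h; on this read-out lower numbers stand for an effect already at smaller amounts and higher numbers for an effect only at larger amounts of compound:
- compound 1 `CC1=NN(S(=O)(=O)c2ccccc2C)C(c2cc(Br)ccc2O)C1`: 39300 nM
- compound 2 `COc1ccc(S(=O)(=O)N2N=C(C)CC2c2cc(Br)ccc2O)cc1`: 38200 nM

Compound 2 holds the lower of the two numbers only nominally: its value of 38200 nM lies within the scatter of the value for compound 1, so the two stand level.

Compound 3 `CC1=NN(S(=O)(=O)c2ccccc2I)C(c2cc(Br)ccc2O)C1` has 2-iodophenyl in place of 4-methoxyphenyl on a sulfonyl sulfur.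

Within the data shown here, only one measured step bears on this change, a 1.0-fold lower number from compound 1 to compound 2 (0.01 log units; within the scatter), and it lies within the scatter. Among the measured compounds shown here, no measured compound carries iodine, so this rests on a single comparison at the same place. For the measured compounds named here, compound 3 is expected to show no step beyond the scatter in this assay since the one exchange at this place gave only a 1.0-fold lower number from compound 1 to compound 2 (0.01 log units; within the scatter). The expected change is a 1.2-fold lower number from compound 2 to compound 3 (0.06 log units; within the scatter), which is estimated to stay within the scatter. For compound 3 the estimated value is 33000 nM, with an expected range of 15000 nM to 70000 nM.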

Compound 3, half-maximal effective concentration: > 60000 nM
Compound 3: a limit, no number (the forecaster's own chance of this, stated with the estimate: 10%); middle value at least 1.8-fold (0.25 log units) away from the limit.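

In this assay compound 3 gives > 60000 nM, which is a limit and not a number. On the sulfonyl sulfur, 2-iodophenyl in place of 4-methoxyphenyl gives an at least 1.5-fold higher number from compound 2 to compound 3 (0.19 log units; that floor lies within the scatter), and iodo in place of methyl on an aromatic carbon gives an at least 1.5-fold higher number from compound 1 to compound 3 (0.18 log units; that floor lies within the scatter). Unlike the exchange between compound 1 and compound 2, which has a readable size, these two steps have only floors, so this position is not shown to tolerate every group, nor is a step beyond the scatter shown, and the reading for compound 3 is the one that stands at the limit: the limit of > 60000 nM in this assay, at which 1 of the 3 values shown sits.

Going by these compounds, the true size of both steps remains open, as does whether the iodine itself sets this reading. A 4-aminophenyl or 4-carboxyphenyl group at this sulfonyl sulfur also remains untested among the compounds shown.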